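A few compounds are considered here, and "the series" means these few. Any claim that something is new, unique, unknown or untested is made for them only; others in the source may bear on it.

Working notes on the series. Going by the values given here, compound 1 `CCN1CCN(c2cn(S(=O)(=O)c3ccc(C(C)C)cc3)c3ccccc23)CC1` gives in an assay on HeLa cells for displacement of a labelled ligand from 5-hydroxytryptamine receptor 6 (Homo sapiens) (on this read-out higher numbers stand for weaker inhibition and lower numbers for stronger inhibition), a value of 8.6 nM, the lower of the two numbers measured so far. Compound 2 `CN1CCN(c2cn(S(=O)(=O)c3ccccc3Br)c3ccc(Br)cc23)CC1` gives in this assay a value of 10.2 nM; it differs from compound 1 in several places at once, and the two values lie within the scatter of each other, so no order between them is claimed. Compound 3 `CCN1CCN(c2cn(S(=O)(=O)c3ccc(C(C)C)cc3)c3ccc(Br)cc23)CC1` has not yet been measured. It differs from compound 1 by bromo in place of hydrogen on an aromatic carbon. Among the compounds with values here, no single step between measured compounds covers this change. Compound 2 does carry a bromine on the shared core and sits close to compound 1, so nothing beyond the scatter is expected in this assay for compound 3. The expected step of a 1.2-fold lower number from compound 1 to compound 3 (0.09 log units; within the scatter) is therefore small. Compound 3 is estimated at 7 nM, with a range from 2.5 nM to 20 nM.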

Compound 3, inhibition constant: 30.1 nM
Compound 3: middle estimate off by 4.3-fold (0.63 log units), on the low side; the measured number lies above the stated range.
By their numbers in this assay, from the lowest: compounds 1 and 2 (each within the scatter of the next); then compound 3.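

Going by these compounds alone, the step of a 3.5-fold higher number from compound 1 to compound 3 (0.54 log units; beyond the scatter) in this assay is the first single-place reading at this aromatic carbon of the shared core, and it lies beyond the scatter. It shows that this position is not indifferent to substitution: replacing hydrogen with bromo, a change of one heavy atom with no ring, no hydrogen-bond donor or acceptor and no net charge, is enough to give a modest weakening. Compound 2 also carries a bromine on the core but differs from compound 1 in several places, so it could not show this, and nothing at hand explains the step.

On these data alone, whether fluoro, chloro, methyl or methoxy on this carbon would give a step of similar size remains open. So does whether an amine or a carboxylic acid here would be tolerated in this assay series.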